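A few compounds are considered here, and "the series" means these few. Any claim that something is new, unique, unknown or untested is made for them only; others in the source may bear on it.

Of the compounds shown here, three have been measured in a functional assay on MCF7 cells (Homo sapiens) for inhibition, with a stated time of 48 h, tested at 50 uM; on this read-out lower numbers stand for less inhibition of growth and higher numbers for more inhibition of growth at the one concentration tested. Compound 1 `C=C[C@@](C)(/C=C/c1ccc(OC)cc1)CCC=C(C)C` gives 18%, compound 3 `COc1ccc(/C=C/[C@@](C)(/C=C/c2ccc(O)cc2)CCC=C(C)C)cc1C=O` gives 36%, and compound 2 `COc1ccc(/C=C/[C@@](C)(/C=C/c2ccc(O)cc2)CCC=C(C)C)cc1` stands highest of the three at 55%. Compound 4 `COc1ccc(/C=C/[C@](C)(/C=C/c2ccc(O)cc2)CCC=C(C)C)cc1` is related to compound 2 as follows: the two compounds have the same atoms and bonds and differ only in configuration as drawn: 1 of 3 stereo elements differ; a stereocentre at a saturated chain carbon is drawn R in compound 2 and S in compound 4. Among the measured compounds shown here, the one measured step, a number 19 percentage points lower from compound 2 to compound 3 (beyond the scatter), is modest and comes from adding a formyl group, so it does not speak to configuration. For the measured compounds named here, no measured pair differs in configuration alone. No shift beyond the scatter is therefore expected in this assay, and no direction can be favoured. The expected step is a number 3 percentage points lower from compound 2 to compound 4 (within the scatter). For compound 4 the estimated value is 52%, with an expected range of 36% to 66%.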

Compound 4, percent growth inhibition at one concentration: 77%
Beside the measured number, compound 4's estimate is 25 percentage points below it; the whole stated range lies below it.
By their numbers in this assay, from the lowest: compound 1; then compound 3; then compound 2; then compound 4.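

Among the compounds shown here, no earlier pair in this assay isolated configuration, but now the stereocentre at a saturated chain carbon, drawn S rather than R, gives a number 22 percentage points higher from compound 2 to compound 4 (beyond the scatter). With 2-(4-hydroxyphenyl)ethenyl in place of vinyl on that carbon, the large step is a number 59 percentage points higher from compound 1 to compound 4 (beyond the scatter). The first of these steps can be assigned to configuration alone because of this: the fact that compounds 2 and 4 differ only in the configuration as drawn. Going by these compounds, whether the S configuration gives a similar shift with the formyl group of compound 3 stays open. So does the effect of an amine in place of the hydroxy group.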